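Bromo for methoxy on the aryl of compound 1

The compounds below may be only part of what the source reports. "The series", "measured", "known", "first", "only" and "open" are said of these compounds alone.

Among the measured compounds shown here, compound 1 `COc1ccc(-n2nc(-c3ccccc3)nc2CNc2ccc(C(=O)NO)cc2)cc1` stands at 63.4% in an assay on Sf9 cells for inhibition of protein deacetylase HDAC6 (Homo sapiens), read by fluorescence, with a stated time of 40 min, tested at 100 nM (a lower number here means less inhibition, a higher number more inhibition at the concentration tested (going by the name of the read-out)), with compound 2 as its only comparison so far. Compound 2 `COc1ccc(-n2nc(-c3ccc(O)cc3)nc2CNc2ccc(C(=O)NO)cc2)cc1` gives 70.3% in this assay , and a number 6.9 percentage points higher from compound 1 to compound 2 (within the scatter). Compound 3 `O=C(NO)c1ccc(NCc2nc(-c3ccccc3)nn2-c2ccc(Br)cc2)cc1` differs from compound 1 by bromo in place of methoxy on an aromatic carbon. For the measured compounds named here, no measured step touches a change of this kind; the single known step, hydroxy for hydrogen, sits inside the scatter and concerns another group. Hence no step beyond the scatter is expected, a number 0.4 percentage points lower from compound 1 to compound 3 (within the scatter). Compound 3 is estimated at 63%, between 45% and 78%.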

Compound 3, a percentage reported as inhibition, at one concentration (the size of the read-out at that concentration, not a potency): 65.9%
Beside the measured number, compound 3's estimate is 2.9 percentage points below it; the range from low to high includes it.
By their numbers in this assay, from the lowest: compounds 1, 3 and 2 (each within the scatter of the next).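

In this assay, going from 4-methoxyphenyl to 4-bromophenyl gives a number 2.5 percentage points higher from compound 1 to compound 3 (within the scatter). Among the compounds shown here, this is the first read on this aromatic carbon, para to a large group: the earlier step concerned the other phenyl, and here methoxy gives way to bromo with the read-out remaining within the scatter at the concentration tested. Nothing available explains this result.

As far as these compounds go, whether an amine, a carboxylic acid or a longer chain at this position would move the read-out beyond the scatter remains open. Also open, from the compounds shown here alone, is how bromo would read alongside the hydroxy of compound 2.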